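The source may report more compounds than this note shows. Statements on the series, on what has been measured and on what is new or still open speak of the compounds shown alone.

Measured so far:
compound 1 `C[C@@]1(c2cc(NC(=O)c3cnc(C(F)F)cn3)ccc2F)C=C(CF)OC(N)=N1` — 2.5
compound 2 `CC1=C[C@@](C)(c2cc(NC(=O)c3ccc(C#N)cn3)ccc2F)N=C(N)O1` — 2.2

In a physicochemical assay for lipophilicity, read by HPLC, in phosphate buffer, measured as octanol-water partition, with a stated time of 1 h, at pH 7.4 (on this read-out higher numbers stand for higher lipophilicity and lower numbers for lower lipophilicity), compound 1 gives 2.5, the highest of the two numbers shown, and compound 2 gives 2.2, a number within the scatter of it, so nothing can be said about an order between them. Compound 3 `COc1cc(C#N)cnc1C(=O)Nc1ccc(F)c([C@]2(C)C=C(CF)OC(N)=N2)c1` is not yet measured. It differs from compound 1 in one place: 5-cyano-3-methoxypyridin-2-yl in place of 5-(difluoromethyl)pyrazin-2-yl on a carbonyl carbon. Among the compounds with values here, no step between two measured compounds covers this change, so the expectation rests on the two values alone. Compound 2 also carries a nitrile and stands at 2.2, close to compound 1, which suggests that the 5-cyano-3-methoxypyridin-2-yl group will move this assay little. The step from compound 1 to compound 3 is expected to be small, a number 0.20 log units lower from compound 1 to compound 3 (within the scatter), and downward if anything. Compound 3 is therefore estimated at 2.3, within a range from 1.9 to 2.7.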

Compound 3, distribution coefficient: 1.9
Compound 3: middle estimate off by 0.40 log units, on the high side; measured number inside the range.
By their numbers in this assay, from the lowest: compounds 3, 2 and 1 (each within the scatter of the next, the first and the last beyond it).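

In this assay, putting 5-cyano-3-methoxypyridin-2-yl in place of 5-(difluoromethyl)pyrazin-2-yl on a carbonyl carbon gives a number 0.60 log units lower from compound 1 to compound 3 (beyond the scatter), so the group on this carbonyl carbon can move the read-out by more than the usual scatter. The change has several parts: the ring goes from two hetero atoms to one, both fluorines leave, and a triple bond and an oxygen enter, so this single step cannot divide its size among these parts. Nothing measured here bears on why the number moves.

The compounds shown leave open which part of the entering group goes with the step, and whether a trifluoromethyl or a chlorine in place of the nitrile would give a similar number. They also leave open how an amine or a carboxylic acid on this ring would read.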